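Amide-bearing pyrazole in place of plain pyrazole

The compounds below may be only part of what the source reports. "The series", "measured", "known", "first", "only" and "open" are said of these compounds alone.

Within the data shown here, in a physicochemical assay for lipophilicity, using the shake flask method, in phosphate buffer, measured as octanol-water partition, with a stated time of 30 min, at pH 7.4 (a higher number here means a more lipophilic compound, a lower number a more polar compound), three compounds have numbers so far. Compound 1 `Cn1cc(-c2cnc(NCc3c(F)ccc4c3CCO4)c3cn[nH]c(=O)c23)cn1` gives 2.7, the second highest of the three; compound 2 `CN(c1ncco1)c1cnc(NCc2c(F)ccc3c2CCO3)n2cnnc12` gives 2.1, and compound 3 `CN(c1ccccc1)c1cnc(NCc2c(F)ccc3c2CCO3)n2cnnc12` gives 3.6. Among the measured compounds shown here, the only single-place step among them, a number 1.50 log units higher from compound 2 to compound 3 (beyond the scatter), shows how far one aromatic ring swapped for another can move this assay. Compound 4 `CNC(=O)c1cc(-c2cnc(NCc3c(F)ccc4c3CCO4)c3cn[nH]c(=O)c23)n(C)n1` is not yet measured. It differs from compound 1 in one place: 1-methyl-3-(methylcarbamoyl)-1H-pyrazol-5-yl in place of 1-methyl-1H-pyrazol-4-yl on an aromatic carbon. For the measured compounds named here, no measured pair mirrors this change, since the shared core of compound 1 and compound 4 is not that of compound 2 and compound 3, so the expectation rests on the counted change alone: the entering group brings a hydrogen-bond donor and an extra acceptor, and on that basis the number for compound 4 is expected to be lower than that of compound 1, the estimated step being a number 0.50 log units lower from compound 1 to compound 4 (beyond the scatter). Compound 4 is therefore estimated at 2.2, with a likely range from 1.6 to 2.8.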

Compound 4, distribution coefficient: 2.1
Compound 4: middle estimate off by 0.10 log units, on the high side, and the stated range covers the measured number.
By their numbers in this assay, from the lowest: compounds 2 and 4 (each within the scatter of the next); then compound 1; then compound 3.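

On the shared core of compound 1, at this aromatic carbon para to a large group, 1-methyl-3-(methylcarbamoyl)-1H-pyrazol-5-yl in place of 1-methyl-1H-pyrazol-4-yl gives a number 0.60 log units lower from compound 1 to compound 4 (beyond the scatter) in this assay. Among these compounds, the only earlier step, a number 1.50 log units higher from compound 2 to compound 3 (beyond the scatter), concerned a different core and a group on a nitrogen, so this is the first reading at this position, and it bundles the added methylcarbamoyl group with the move from a 4-yl to a 5-yl attachment. Nothing shown gives a measured reason for the step.

The compounds shown leave open how much of the step belongs to the methylcarbamoyl group and how much to the change of attachment, which plain 1-methyl-1H-pyrazol-5-yl at this place would separate. They also leave open how a carboxylic acid or an N,N-dimethylamide on the same ring would read.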